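The source may report more compounds than this note shows. Statements on the series, on what has been measured and on what is new or still open speak of the compounds shown alone.

Working notes on the series. The three measured compounds share one core and differ only in the aryl group attached to it. Compound 1 `O=C(CCCCC1CCSS1)NCc1cn(CCCCCOc2ccc3cc(-c4ccccc4)c(=O)oc3c2)nn1` carries a bare phenyl; in a functional assay on PC-12 cells (Rattus norvegicus) for cytotoxicity, read by MTT assay, with stated times of 3 h and 2 h, tested at 50 uM (on this read-out lower numbers stand for a weaker effect and higher numbers for a stronger effect at the one concentration tested), compound 1 gives 17.7%. Compound 2 `COc1ccc(-c2cc3ccc(OCCCCCn4cc(CNC(=O)CCCCC5CCSS5)nn4)cc3oc2=O)cc1` gives 52.8% in this assay, and compound 3 `COc1ccc(-c2cc3ccc(OCCCCCn4cc(CNC(=O)CCCCC5CCSS5)nn4)cc3oc2=O)cc1OC` gives 55%. Compound 3 holds the highest of the three numbers, but the gap a number 2.2 percentage points higher from compound 2 to compound 3 (within the scatter) lies within the scatter, so compound 2 and compound 3 cannot be ordered. Both stand clearly apart from compound 1: a number 35.1 percentage points higher from compound 1 to compound 2 (beyond the scatter) and a number 37.3 percentage points higher from compound 1 to compound 3 (beyond the scatter).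

Compound 4 `O=C(CCCCC1CCSS1)NCc1cn(CCCCCOc2ccc3cc(-c4ccc(Br)cc4)c(=O)oc3c2)nn1` remains to be measured. The change from compound 3 is 4-bromophenyl in place of 3,4-dimethoxyphenyl on an aromatic carbon. Within the data shown here, no measured step introduces bromine, so the only bearing evidence is indirect: removing both methoxy groups from compound 3 to reach compound 1 is the large reverse of a number 37.3 percentage points higher from compound 1 to compound 3 (beyond the scatter), and a single methoxy on compound 2 already accounts for nearly the whole rise, a number 35.1 percentage points higher from compound 1 to compound 2 (beyond the scatter). Compound 4 loses both methoxy groups and gains a substituent of unknown effect, so a downward step is expected, a number 22 percentage points lower from compound 3 to compound 4 (beyond the scatter), landing between compound 1 and compound 2 with wide uncertainty. Compound 4 is therefore estimated at 33%, within 15% to 55%.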

Compound 4, a percentage reported as activity, at one concentration (the size of the read-out at that concentration, not a potency): 53.6%
Compound 4: the middle estimate sits 20.6 percentage points below what was measured; measured number inside the range.
By their numbers in this assay, from the lowest: compound 1; then compounds 2, 4 and 3 (each within the scatter of the next).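

In this assay, the rise over the bare phenyl of compound 1 does not depend on a methoxy group: bromo in place of hydrogen gives a number 35.9 percentage points higher from compound 1 to compound 4 (beyond the scatter) and 4-bromophenyl has 0 hydrogen-bond acceptors. Bromo in place of methoxy gives a number 0.8 percentage points higher from compound 2 to compound 4 (within the scatter) and 4-bromophenyl in place of 3,4-dimethoxyphenyl gives a number 1.4 percentage points lower from compound 3 to compound 4 (within the scatter) so, despite the loss of both oxygen atoms and the drop in heavy atoms in the group, compound 2, compound 3 and compound 4 cannot be ordered at this position. Nothing available explains why these three substituted compounds stand apart from compound 1 or why they cannot be separated from one another.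

The compounds shown leave open whether an amine, a hydroxyl or a carboxylic acid on the phenyl would also stand apart from compound 1, and whether bromo at another place on that ring would match the 4-bromophenyl group. They also leave open whether a longer linking chain would change the read-out, and how these compounds compare at concentrations other than the one tested.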